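Removing One Methoxy Group: Compound 2 to Compound 3

The compounds below may be only part of what the source reports. "The series", "measured", "known", "first", "only" and "open" are said of these compounds alone.

Of the compounds shown here, two sharing the same core have been measured in a functional assay on PC-3 cells (Homo sapiens) for cytotoxicity, read by sulforhodamine B assay, with a stated time of 48 h; on this read-out lower numbers stand for stronger inhibition and higher numbers for weaker inhibition. Compound 1 `COc1cc(C2CC(c3ccc4ccccc4c3)=NN2CC=O)cc(OC)c1OC` gives 570 nM in this assay. Compound 2 `COc1ccc(C2CC(c3ccc4ccccc4c3)=NN2CC=O)c(OC)c1OC` gives 610 nM in this assay, the higher of the two numbers, though its gap to compound 1 lies within the usual scatter, so no order between them can be claimed. Compound 3 `COc1ccc(C2CC(c3ccc4ccccc4c3)=NN2CC=O)cc1OC` has not yet been measured. It differs from compound 2 in one place: hydrogen in place of methoxy on an aromatic carbon. Among the compounds with values here, no measured pair in this set shows what such a change does here, so the step can only be expected, not read from data. For compound 3 a modest rise in number, a somewhat weaker inhibition, is estimated, with the step from compound 2 given as a 2.0-fold higher number from compound 2 to compound 3 (0.29 log units; within the scatter). The estimated value for compound 3 is 1200 nM, expected to fall between 400 nM and 3500 nM.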

Compound 3, half-maximal inhibitory concentration: 1980 nM
Compound 3: middle estimate off by 1.7-fold (0.22 log units), on the low side, within the range that was stated.
By their numbers in this assay, from the lowest: compounds 1 and 2 (each within the scatter of the next); then compound 3.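

In this assay, replacing a methoxy group on an aromatic carbon with hydrogen gives a 3.2-fold higher number from compound 2 to compound 3 (0.51 log units; beyond the scatter) and, at another place on the same ring, a 3.5-fold higher number from compound 1 to compound 3 (0.54 log units; beyond the scatter), so this change now has a measured size in both directions of comparison with compound 3. Compound 1 and compound 2 carry the third methoxy group at different places and cannot be ordered, yet compound 3, which lacks it, stands apart from each, including at the carbon in compound 2 that is ortho to a large group. Nothing available explains why the number rises.

The compounds shown leave open how a hydroxyl group, an amine or an ethoxy chain on that carbon would compare with methoxy and hydrogen. They also leave open what removing either methoxy group kept in compound 3 would do.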